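The compounds below may be only part of what the source reports. "The series", "measured", "known", "first", "only" and "open" are said of these compounds alone.

Compound 1 `O=C(Nc1cc(Oc2ccc(Nc3nccc4[nH]cc(-c5ccc(F)cc5)c(=O)c34)cc2F)ccn1)C1CCC1` gives 46% in a functional assay on HT-29 cells (Homo sapiens) for antiproliferative activity, read by MTT assay, with a stated time of 72 h, tested at 10 uM; a lower number here means less inhibition, a higher number more inhibition at the concentration tested (going by the name of the read-out).
Compound 2 `CCCCC(=O)Nc1cc(Oc2ccc(Nc3nccc4[nH]cc(-c5ccc(F)cc5)c(=O)c34)cc2F)ccn1` gives -42.2% in this assay.

Compound 2 stands lowest of the two numbers in this assay; its nearest neighbour is compound 1, reached by a number 88.2 percentage points lower from compound 1 to compound 2 (beyond the scatter). Compound 3 `CC(C)(C)C(=O)Nc1cc(Oc2ccc(Nc3nccc4[nH]cc(-c5ccc(F)cc5)c(=O)c34)cc2F)ccn1` differs from compound 2 by tert-butyl in place of butyl on a carbonyl carbon. Within the data shown here, the only measured step that bears on this is the one from compound 1 to compound 2, where the same four carbons changed their arrangement and the number fell far beyond the scatter. Among the measured compounds shown here, a rise is therefore expected in this assay, though only one step supports it. For compound 3 the estimate is 15%, within -35% to 55%, an expected step of a number 57.2 percentage points higher from compound 2 to compound 3 (beyond the scatter).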

Compound 3, a percentage reported as inhibition, at one concentration (the size of the read-out at that concentration, not a potency): -45.8%
Compound 3: middle estimate off by 60.8 percentage points, on the high side; measured number below the stated range.
By their numbers in this assay, from the lowest: compounds 3 and 2 (each within the scatter of the next); then compound 1.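

In this assay, tert-butyl and butyl on the carbonyl carbon read alike (a number 3.6 percentage points lower from compound 2 to compound 3 (within the scatter)), while cyclobutyl stands well apart from tert-butyl (a number 91.8 percentage points lower from compound 1 to compound 3 (beyond the scatter)). Among these three compounds, then, the two open-chain groups cannot be told apart, and only the cyclobutyl of compound 1 gives the higher number. No measurement at hand explains this separation.
From the compounds shown here alone, whether the higher number belongs to cyclobutyl alone or extends to other rings, such as cyclopropyl or cyclopentyl, remains open. So does the outcome with a shorter chain, such as ethyl, or an amine at this carbon.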